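The source may report more compounds than this note shows. Statements on the series, on what has been measured and on what is new or still open speak of the compounds shown alone.

Compound 2 `COc1ccc(CNCCCNS(=O)(=O)c2cc(C(F)(F)F)cc(C(F)(F)F)c2)cc1OC` and compound 1 `CC(C)(C)c1ccc(CNCCCNS(=O)(=O)c2cc(C(F)(F)F)cc(C(F)(F)F)c2)cc1` share one core and differ only in the aromatic group attached to a saturated chain carbon bound to an amine nitrogen. In a functional assay on BE(2)-C cells (Homo sapiens) for inhibition, read by MTT assay, with a stated time of 72 h (on this read-out higher numbers stand for weaker inhibition of growth and lower numbers for stronger inhibition of growth), compound 1 gives 2500 nM, and in the same setting compound 2 gives 3600 nM, which is the higher of the two numbers, though the step of a 1.4-fold higher number from compound 1 to compound 2 (0.16 log units; within the scatter) lies within the scatter. Compound 3 `O=S(=O)(NCCCNCc1ccc(Cl)c(C(F)(F)F)c1)c1cc(C(F)(F)F)cc(C(F)(F)F)c1` is obtained from compound 2 by the change (4-chloro-3-(trifluoromethyl)phenyl in place of 3,4-dimethoxyphenyl on a saturated chain carbon bound to an amine nitrogen). Among the measured compounds shown here, the only measured step that bears on this kind of swap is the one from compound 1 to compound 2, in which exchanging one aromatic group for another at the same place left this assay essentially unchanged. On that basis the step of a 1.3-fold lower number from compound 2 to compound 3 (0.11 log units; within the scatter) is expected to stay within the scatter, with no clear direction. Compound 3 is therefore estimated at 2800 nM in this assay, with a plausible range from 1000 nM to 7000 nM.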

Compound 3, concentration for 50% growth inhibition: 8600 nM
Estimate against measurement, compound 3: 3.1-fold (0.49 log units) below; measured number above the stated range.
By their numbers in this assay, from the lowest: compounds 1 and 2 (each within the scatter of the next); then compound 3.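

In this assay this position proves sensitive to the choice of aromatic group: a 2.4-fold higher number from compound 2 to compound 3 (0.38 log units; beyond the scatter) and a 3.4-fold higher number from compound 1 to compound 3 (0.54 log units; beyond the scatter) both lie beyond the scatter, although both are modest, whereas the exchange between the two earlier groups did not. Among the three compounds, 4-chloro-3-(trifluoromethyl)phenyl therefore gives weaker inhibition of growth than either 3,4-dimethoxyphenyl or 4-(tert-butyl)phenyl, so a swap at this place cannot be assumed to be neutral. No measurement shown gives a reason for this shift.

As far as these compounds go, the chlorine and the trifluoromethyl appear together here, so their separate contributions remain open. A phenyl group carrying only the chlorine, one carrying only the trifluoromethyl and an unsubstituted phenyl group would each help to show which part of the group goes with the change.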